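A few compounds are considered here, and "the series" means these few. Any claim that something is new, unique, unknown or untested is made for them only; others in the source may bear on it.

Measured compounds:
compound 1 `CC(C)C(=O)Nc1ccc(S(=O)(=O)Oc2ccccc2C(C)C)cc1`: 8600 nM
compound 2 `CC(C)C(=O)Nc1ccc(S(=O)(=O)Oc2ccccc2I)cc1`: 8100 nM
compound 3 `CC(C)c1ccccc1OS(=O)(=O)c1ccc(NC(=O)NCC2CCCC2)cc1`: 7100 nM

All three were read in a functional assay on MCF7 cells (Homo sapiens) for antiproliferative activity, read by sulforhodamine B assay, with a stated time of 48 h; a lower number here means a stronger inhibitor, a higher number a weaker inhibitor; the values of compound 2 and compound 3 lie within the scatter of each other. Compound 2 arises from compound 1 by iodo in place of isopropyl on an aromatic carbon, a change that gave a 1.1-fold lower number from compound 1 to compound 2 (0.03 log units; within the scatter). The cores of compound 1 and compound 3 differ by (cyclopentylmethyl)amino in place of isopropyl on a carbonyl carbon, with a 1.2-fold lower number from compound 1 to compound 3 (0.08 log units; within the scatter). Compound 4 `O=C(NCC1CCCC1)Nc1ccc(S(=O)(=O)Oc2ccccc2I)cc1` is not yet measured. It differs from compound 3 by iodo in place of isopropyl on an aromatic carbon, the same change as that from compound 1 to compound 2, at a place described in the same words. Because a 1.1-fold lower number from compound 1 to compound 2 (0.03 log units; within the scatter) stayed within the scatter, the step expected in this assay is a 1.1-fold lower number from compound 3 to compound 4 (0.04 log units; within the scatter). Compound 4 is therefore estimated at 6500 nM, with a range from 3500 nM to 12000 nM expected.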

Compound 4, half-maximal inhibitory concentration: 6600 nM
The estimate for compound 4 lay 1.0-fold (0.01 log units) below the measured number, within the range that was stated.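

In this assay, iodo in place of isopropyl on an aromatic carbon gave a 1.1-fold lower number from compound 3 to compound 4 (0.03 log units; within the scatter), which agrees with the same change on the other core: the same change on two cores in this assay, a 1.1-fold lower number (0.03 log units; within the scatter) from compound 1 to compound 2 and a 1.1-fold lower number (0.03 log units; within the scatter) from compound 3 to compound 4, 1.0-fold (0.01 log units) apart, within the scatter of two such steps. The change on the carbonyl carbon gave a 1.2-fold lower number from compound 2 to compound 4 (0.09 log units; within the scatter), which also agrees with its earlier step: the same change on two cores in this assay, a 1.2-fold lower number (0.08 log units; within the scatter) from compound 1 to compound 3 and a 1.2-fold lower number (0.09 log units; within the scatter) from compound 2 to compound 4, 1.0-fold (0.01 log units) apart, within the scatter of two such steps. Both changes therefore carry between these two cores without a detectable difference, but every step lies within the scatter, so this does not show that a change with a step beyond the scatter would carry over in the same way.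

Still open, as far as these compounds go, is whether methoxy in place of iodo, or a carboxylic acid or a longer chain in place of cyclopentylmethyl, would give a step beyond the scatter in this assay.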